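Three measured compounds and a fourth to be judged

This account rests on a few compounds, and the source may have more. Where it says the series, first, only, none or still open, it means among the compounds named here.

Compound 1 `Cc1ccc(S(=O)(=O)NC2=NCCN2C(=S)SN2CCn3c2nsc3=S)cc1` gives >= 20000 nM in a functional assay on KYSE-510 cells (Homo sapiens) for antiproliferative activity, read by crystal violet staining, with a stated time of 96 h (on this read-out higher numbers stand for weaker inhibition of growth and lower numbers for stronger inhibition of growth), a value that is a limit of the assay rather than a number.
Compound 2 `COc1ccc(OC)c(S(=O)(=O)NC2=NCCN2C(=S)SN2CCn3c2nsc3=S)c1` gives >= 20000 nM in this assay, again a limit.
Compound 3 `O=S(=O)(NC1=NCCN1C(=S)SN1CCn2c1nsc2=S)c1ccc(Cl)cc1` gives >= 20000 nM in this assay, also a limit.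

All three share one core and differ only in the aryl group on the sulfonyl sulfur. Where compound 1 stands is known only as a limit: the limit of >= 20000 nM in this assay, at which 3 of the 3 values shown sit. So the steps among the measured compounds cannot be read: a step that the two limits leave unreadable from compound 1 to compound 2, a step that the two limits leave unreadable from compound 1 to compound 3 and a step that the two limits leave unreadable from compound 2 to compound 3 each run between two limits and show neither size nor direction.

Compound 4 `O=S(=O)(NC1=NCCN1C(=S)SN1CCn2c1nsc2=S)c1ccc(Cl)c(Cl)c1` is the next change: 3,4-dichlorophenyl in place of 4-methylphenyl on a sulfonyl sulfur. Going by the values given here, the steps that bear on it are those that swap the group on the sulfonyl sulfur, and every one of them is unreadable. With a 4-methylphenyl, a 2,5-dimethoxyphenyl and a 4-chlorophenyl all sitting at the same limit, the 3,4-dichlorophenyl is expected to behave alike in this assay. The expected step of a number no higher from compound 1 to compound 4 (the limit leaves the size open) is therefore none beyond the scatter, and compound 4 will most probably again show only a limit. Compound 4 is estimated at 20000 nM, between 8000 nM and 50000 nM.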

Compound 4, concentration for 50% growth inhibition: >= 20000 nM
Compound 4: no number, only a limit (the forecaster's own chance of this, stated with the estimate: 85%); the middle value sits exactly at the limit.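

Compound 4 gives >= 20000 nM in this assay, again a limit and not a number. Its steps to compound 1, compound 2 and compound 3 therefore cannot be read: the limit of >= 20000 nM in this assay, at which 4 of the 4 values shown sit.

The compounds shown leave open whether any group on the sulfonyl sulfur can give a growth inhibition that reads as an actual number.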